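This account rests on a few compounds, and the source may have more. Where it says the series, first, only, none or still open, it means among the compounds named here.

Compound 3 `COc1cc(Cc2cc(C)nn(CC(=O)Nc3ccc(I)cc3)c2=O)cc(OC)c1` gives in a functional assay on HL-60 cells (Homo sapiens), read by calcium flux (a lower number here means that less compound is needed, a higher number that more compound is needed for the effect), only a limit, > 50000 nM. Compound 2 `COc1cc(Cc2cc(C)nn(CC(=O)Nc3ccc(Br)cc3)c2=O)cc(OC)c1` likewise gives in this assay a limit, > 50000 nM. Compound 1 `Cc1cc(Cc2cccc(Cl)c2)c(=O)n(CC(=O)Nc2ccc(Br)cc2)n1` also gives in this assay a limit, > 50000 nM. Accordingly a step that the two limits leave unreadable from compound 1 to compound 2 and a step that the two limits leave unreadable from compound 2 to compound 3, the whole series resting at the limit of > 50000 nM in this assay, at which 3 of the 3 values shown sit. Compound 4 `Cc1cc(Cc2cccc(Cl)c2)c(=O)n(CC(=O)Nc2ccc(I)cc2)n1` differs from compound 3 by 3-chlorophenyl in place of 3,5-dimethoxyphenyl on a saturated chain carbon bound to an aromatic carbon. Within the data shown here, the only measured step bearing on this change is the reverse of the one from compound 1 to compound 2, and the limits leave it unreadable; the iodo on an aromatic carbon is kept. No direction can be read, and a further limit is the expected outcome. For compound 4 the estimate is 70000 nM, within 20000 nM to 300000 nM. That expected step is a step that the limit leaves unreadable from compound 3 to compound 4.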

Compound 4, half-maximal effective concentration: > 50000 nM
Compound 4 gave a limit, no number; the forecaster's own chance of this, stated with the estimate: 85%; the middle value lies beyond the limit too.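

Compound 4 gives only a limit, so its steps from compound 3 and from compound 1 cannot be read: the limit of > 50000 nM in this assay, at which 4 of the 4 values shown sit. As far as these compounds go, whether either change alters the response in this assay stays open.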